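A Methoxy Group Added to a Weak Cytotoxic Amide

The source may hold more compounds than are shown below. What is called first, only, known or untested is meant among the compounds shown, and "the series" means these compounds.

Three amides built on one shared core have been tested in a functional assay on MCF7 cells (Homo sapiens) for cytotoxicity, read by MTT assay, with a stated time of 72 h; on this read-out higher numbers stand for weaker inhibition and lower numbers for stronger inhibition. Compound 1 `O=C(Nc1ccc(Oc2ccnc3[nH]ccc23)cc1)c1cc(-c2ccccc2)ccn1` gives 3750 nM. Compound 2 `O=C(Nc1ccc(Oc2ccnc3[nH]ccc23)c(F)c1)c1ccc(-c2ccc(F)cc2)cn1` reaches only a limit of the assay, > 10000 nM. Compound 3 `O=C(Nc1ccc(Oc2ccnc3[nH]ccc23)c(F)c1)c1cc(-c2ccccc2)ccn1` likewise gives only a limit, > 10000 nM. Among the measured compounds shown here, the one step that can be followed among them, an at least 2.6-fold higher number from compound 1 to compound 3 (0.42 log units; beyond the scatter), is a fluoro in place of hydrogen on an aromatic carbon, and it runs into (the limit of > 10000 nM in this assay, at which 2 of the 3 values shown sit), so its full size is not known. Compound 3 thus stands at the weak end of what the numbers show, without a number of its own.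

Compound 4 `COc1ccc(-c2ccnc(C(=O)Nc3ccc(Oc4ccnc5[nH]ccc45)c(F)c3)c2)cc1` differs from compound 3 in one place: methoxy in place of hydrogen on an aromatic carbon. For the measured compounds named here, no measured step tells how a methoxy at this place changes the read-out here. The fluoro step and the fluoro-bearing compound 2 concern other groups and give no guide for a methoxy. What carries over is that compound 3 starts at a limit, so even a real gain might leave compound 4 with no number. Compound 4 is therefore expected near 12000 nM, within 4000 nM to 40000 nM, most likely again reported as a limit. The expected step is a step that the limit leaves unreadable from compound 3 to compound 4, nothing beyond the scatter.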

Compound 4, half-maximal inhibitory concentration: 9110 nM
Beside the measured number, compound 4's estimate is 1.3-fold (0.12 log units) above it; measured number inside the range.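

In this assay, the change from phenyl to 4-methoxyphenyl gives an at least 1.0-fold lower number from compound 3 to compound 4 (0.04 log units; that floor lies within the scatter), so the step is known only as a floor, and that floor alone supports no claim of a gain. Even so, of the compounds shown that carry the fluoro on the shared core, only compound 4 gives a real number, 9110 nM, which shows that a methoxy on this six-membered aromatic ring of carbon only, para to a large group, still leaves a value the assay can read. The full size of the step stays unknown because compound 3 has no number of its own: the limit of > 10000 nM in this assay, at which 2 of the 4 values shown sit.

Still open, going by these compounds, is whether another group at this same place, such as an amine, a carboxylic acid or a longer chain like ethoxy, would move the number clearly beyond the scatter. Also open, on these data alone, is how the same methoxy would read on compound 1, which gives 3750 nM, a true number rather than a limit, so that a step starting from it could be read in full.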